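Swapping the Fluorophenyl for a Dichlorophenyl on the Hydrazone

This account rests on a few compounds, and the source may have more. Where it says the series, first, only, none or still open, it means among the compounds named here.

Compound 3 `COc1cc(C(=O)N/N=C/c2ccc(F)cc2)cc(OC)c1OC` stands highest of the three compounds measured in a functional assay on BGC-823 cells (Homo sapiens) for antiproliferative activity, read by MTT assay, tested at 1 uM; a lower number here means a weaker effect, a higher number a stronger effect of the compound at the concentration tested; compound 3 gives 50.9%. Compound 1 `COc1cc(C(=O)N/N=C/c2cccc(F)c2)cc(OC)c1OC` gives 13.6% and compound 2 `COc1cc(C(=O)N/N=C/c2c(Cl)cccc2Cl)cc(OC)c1OC` gives 0.9%. The change to compound 4 `COc1cc(C(=O)N/N=C/c2cc(Cl)cc(Cl)c2)cc(OC)c1OC` is 3,5-dichlorophenyl in place of 4-fluorophenyl on a carbon with a double bond to nitrogen. Among the measured compounds shown here, two measured steps bear on it, both ending at compound 3: a number 37.3 percentage points higher from compound 1 to compound 3 (beyond the scatter) and a number 50 percentage points higher from compound 2 to compound 3 (beyond the scatter). Each move onto 4-fluorophenyl from another substitution pattern, one of them a dichlorophenyl, raised the read-out by a large amount, so leaving 4-fluorophenyl for 3,5-dichlorophenyl is expected to lower the read-out in this assay, probably by a large step. Compound 4 is therefore expected to fall near 15%, within 0% to 40%. This is expected to amount to a number 35.9 percentage points lower from compound 3 to compound 4 (beyond the scatter).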

Compound 4, a percentage reported as inhibition, at one concentration (the size of the read-out at that concentration, not a potency): -7.5%
The estimate for compound 4 lay 22.5 percentage points above the measured number; the whole stated range lies above it.
By their numbers in this assay, from the lowest: compounds 4 and 2 (each within the scatter of the next); then compound 1; then compound 3.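

In this assay, the drop on leaving 4-fluorophenyl (a number 58.4 percentage points lower from compound 3 to compound 4 (beyond the scatter)) shows that 3,5-dichlorophenyl, and not only the 2,6-dichlorophenyl group of compound 2, gives a low read-out at this position. The two dichlorophenyl patterns do not separate (a number 8.4 percentage points lower from compound 2 to compound 4 (within the scatter)), while 3,5-dichlorophenyl also stands lower than 3-fluorophenyl (a number 21.1 percentage points lower from compound 1 to compound 4 (beyond the scatter)). No measurement shown here accounts for these differences. The compounds shown leave open whether a phenyl carrying a single chlorine, an amine or a carboxylic acid would hold the read-out of compound 3.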